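Compound 2 to compound 3: an expected step

The source may report more compounds than this note shows. Statements on the series, on what has been measured and on what is new or still open speak of the compounds shown alone.

Measured so far in a physicochemical assay for lipophilicity, at pH 7.4; on this read-out higher numbers stand for higher lipophilicity and lower numbers for lower lipophilicity:
- compound 1 (`Cc1cc(C(=O)O)nn1C(C)c1cc(Cl)ccc1OCc1ccccc1`) gives (1)
- compound 2 (`Cc1cc(C(=O)Nc2ccccn2)nn1Cc1cc(Cl)ccc1OCc1ccccc1`) gives (> 3.7), a limit of the assay

In this assay compound 2 carries only a limit (> 3.7) and no number. Compound 3 (`CC(=O)Nc1cc(C)n(Cc2cc(Cl)ccc2OCc2ccccc2)n1`) has acetamido in place of (pyridin-2-yl)carbamoyl on an aromatic carbon. Among the measured compounds shown here, no measured pair isolates this change, so the expectation rests on the structural difference alone. A moderate step down in this assay is expected, and the result could still fall at the limit. The estimate is (a number at least 0.40 log units lower from compound 2 to compound 3 (beyond the scatter)) for this step. The estimated value for compound 3 is 3.3 (expected range 2.7 to 3.7).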

Compound 3, distribution coefficient: > 3.7
Compound 3 gave a limit, no number; the forecaster's own chance of this, stated with the estimate: 25%; at least 0.40 log units between middle value and limit.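

In this assay compound 2 and compound 3 both sit at a limit of the assay, so no step can be read between them: the limit of > 3.7 in this assay, at which 2 of the 3 values shown sit. Still open, from the compounds shown here alone, is how far, and in which direction, acetamido in place of (pyridin-2-yl)carbamoyl moves this read-out.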